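Furan-2-yl to furan-3-yl: an expected growth-inhibition step

The source may hold more compounds than are shown below. What is called first, only, known or untested is meant among the compounds shown, and "the series" means these compounds.

Compound 1 `CCCCCCCCCCCC[C@@H](O)[C@H]1CC[C@H]([C@H](O)CCCCCCCCCCNC(=O)c2cccs2)O1`: 3310 nM
Compound 2 `CCCCCCCCCCCC[C@@H](O)[C@H]1CC[C@H]([C@H](O)CCCCCCCCCCNC(=O)c2ccco2)O1`: 100000 nM

In a functional assay on MKN-45 cells (Homo sapiens) for inhibition, read by colorimetric assay and sulforhodamine B assay, with a stated time of 48 h (on this read-out lower numbers stand for stronger inhibition of growth and higher numbers for weaker inhibition of growth), compound 2 stands highest of the two, at 100000 nM. Compound 3 `CCCCCCCCCCCC[C@@H](O)[C@H]1CC[C@H]([C@H](O)CCCCCCCCCCNC(=O)c2ccoc2)O1` carries furan-3-yl in place of furan-2-yl on a carbonyl carbon. Among the compounds with values here, only one measured step bears on this change, and it is large: a 30-fold higher number from compound 1 to compound 2 (1.48 log units; beyond the scatter). Within the data shown here, that step swaps the ring rather than its point of attachment, so it shows only that this group can move the number far. A moderate move to a lower number is therefore expected, and the estimated change is a 3.3-fold lower number from compound 2 to compound 3 (0.52 log units; beyond the scatter). For compound 3 the expected value is 30000 nM, with an estimated range of 4000 nM to 120000 nM.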

Compound 3, concentration for 50% growth inhibition: 100000 nM
Compound 3: the middle estimate sits 3.3-fold (0.52 log units) below what was measured, within the range that was stated.
By their numbers in this assay, from the lowest: compound 1; then compounds 2 and 3 (each within the scatter of the next).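

In this assay, furan-3-yl in place of furan-2-yl on the carbonyl carbon gives no change at the digits printed from compound 2 to compound 3 (within the scatter) so the point of attachment does not separate the two furans here. Furan-3-yl in place of thiophen-2-yl gives a 30-fold higher number from compound 1 to compound 3 (1.48 log units; beyond the scatter) in line with the step already seen for furan-2-yl, so the gap to compound 1 holds for both furans. Nothing given here accounts for this gap. On these data alone, whether thiophen-3-yl would stand with compound 1 or with the furans remains open, as does how a phenyl or pyridin-2-yl ring on the same carbonyl carbon would read.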